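Swapping the aryl ether tail: chloro-methyl for nitro

A few compounds are considered here, and "the series" means these few. Any claim that something is new, unique, unknown or untested is made for them only; others in the source may bear on it.

Compound 1, with structure `CCCc1nc2ccccc2c(=O)n1/N=C/c1ccc(Oc2ccc(Cl)c(C)c2)cc1`, is one of three related compounds measured in a physicochemical assay for lipophilicity, in phosphate buffer, measured as octanol-water partition; on this read-out higher numbers stand for higher lipophilicity and lower numbers for lower lipophilicity. Compound 1 gives 6.02, the second highest of the three numbers. Compound 2, `Cc1cc(Oc2ccc(/C=N/n3c(C)nc4ccccc4c3=O)cc2)ccc1Cl`, gives 4.41, and compound 3, `Cc1cc(Oc2ccc(/C=N/n3c(-c4ccccc4)nc4ccccc4c3=O)cc2)ccc1Cl`, gives 6.52. The steps among them all change the group on the shared core: a number 1.61 log units lower from compound 1 to compound 2 (beyond the scatter), a number 0.50 log units higher from compound 1 to compound 3 (beyond the scatter) and a number 2.11 log units higher from compound 2 to compound 3 (beyond the scatter).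

Compound 4, `CCCc1nc2ccccc2c(=O)n1/N=C/c1ccc(Oc2ccc([N+](=O)[O-])cc2)cc1`, differs from compound 1 in a different place: 4-nitrophenyl in place of 4-chloro-3-methylphenyl on an oxygen on an aromatic ring. Among the compounds with values here, none of the measured steps touches this part of the molecule, so none bears directly on the new change; they only show that a single group can move this read-out by a large amount. Trading a ring that carries a chlorine and a methyl for one that carries a nitro group, with its two hydrogen-bond acceptors, is expected to lower this assay clearly, by a step estimated as a number 1.52 log units lower from compound 1 to compound 4 (beyond the scatter). Compound 4 is therefore estimated at 4.5, with a likely range from 3.9 to 5.1.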

Compound 4, partition coefficient: 5.18
For compound 4 the middle estimate is 0.68 log units below the measured one; measured number above the stated range.
By their numbers in this assay, from the lowest: compound 2; then compound 4; then compound 1; then compound 3.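

In this assay, the aryl ether tail proves to be a position that can shift the read-out: with 4-nitrophenyl in place of 4-chloro-3-methylphenyl on the oxygen, the result is a number 0.84 log units lower from compound 1 to compound 4 (beyond the scatter). This step is modest, whereas changing the group on the shared core can give a large one, such as a number 1.61 log units lower from compound 1 to compound 2 (beyond the scatter), so within this small set the tail swap does not produce the biggest shift. Nothing shown here explains why this swap moves the read-out by this amount.

This single swap removes a chlorine and a methyl and adds a nitro group all at once, so a simpler tail such as 4-chlorophenyl or 3-methylphenyl would be needed to show how much each part contributes, and a tail carrying an amine or a carboxylic acid would show how far the read-out can move at this position. On these data alone, it also remains open whether the same swap gives a step of similar size when methyl or phenyl replaces propyl on the shared core.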